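The source may hold more compounds than are shown below. What is called first, only, known or untested is meant among the compounds shown, and "the series" means these compounds.

Compounds measured so far:

compound 1, `COc1cc2cc(Oc3ccc(NC(=O)Nc4ccccc4)cc3)c(C)nc2cc1OC`, in a functional assay on SK-MEL-5 cells (Homo sapiens) for inhibition, read by sulforhodamine B assay, with a stated time of 48 h, tested at 10 uM (a lower number here means a stronger effect, a higher number a weaker effect of the compound at the concentration tested), compound 1 gives 60.8%
compound 2, `COc1cc2cc(Oc3ccc(NC(=O)Nc4ccc(C)cc4)cc3)c(C)nc2cc1OC`, in this assay compound 2 gives 100%

Compound 2 stands highest of the two numbers in this assay; its nearest neighbour is compound 1, and the step of a number 39.2 percentage points higher from compound 1 to compound 2 (beyond the scatter) lies beyond the scatter and is large, so compound 2 shows the weaker effect of the two at the concentration tested.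

Compound 3, `COc1cc2cc(Oc3ccc(NC(=O)Nc4ccc(C(F)(F)F)cc4)cc3)c(C)nc2cc1OC`, has not been measured. It differs from compound 2 in one place: trifluoromethyl in place of methyl on an aromatic carbon.

Within the data shown here, no measured step follows the same change. Among the measured compounds shown here, the only step known, a number 39.2 percentage points higher from compound 1 to compound 2 (beyond the scatter), concerns methyl in place of hydrogen on the same aromatic carbon and shows that this position is sensitive in this assay, but it does not tell in which direction a trifluoromethyl in place of the methyl would move the number. Since compound 2 already stands at the top of the range, the step of a number 15 percentage points lower from compound 2 to compound 3 (beyond the scatter) is expected to be small or downward rather than upward. Compound 3 is therefore expected to give about 85% in this assay, within 50% to 100%.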

Compound 3, a percentage reported as activity, at one concentration (the size of the read-out at that concentration, not a potency): 47.4%
For compound 3 the middle estimate is 37.6 percentage points above the measured one; measured number outside the range, below it.
By their numbers in this assay, from the lowest: compound 3; then compound 1; then compound 2.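

The new value shows that this aromatic carbon does not respond in one direction to substitution: in this assay, methyl gave a number 39.2 percentage points higher from compound 1 to compound 2 (beyond the scatter), whereas trifluoromethyl in place of that methyl gave a number 52.6 percentage points lower from compound 2 to compound 3 (beyond the scatter). Trifluoromethyl also takes the number past the hydrogen-bearing parent, with a number 13.4 percentage points lower from compound 1 to compound 3 (beyond the scatter), so compound 3 shows the strongest effect of the three at the concentration tested and the two substituents fall on opposite sides of compound 1. No measurement shown here explains why two groups on the same carbon, each with no hydrogen-bond donors or acceptors, move the number in opposite directions.

The three compounds leave open how this carbon would respond to other groups, such as a single fluorine, a chlorine, a methoxy group or an amine, and so whether the opposite steps seen with methyl and trifluoromethyl belong to a wider trend. Each number is also read at a single concentration on one cell line, so these values give no potency for any of the compounds and do not show whether their order would hold at other concentrations.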